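The source may report more compounds than this note shows. Statements on the series, on what has been measured and on what is new or still open speak of the compounds shown alone.

In an ADME assay on Vero 76 cells (Chlorocebus sabaeus) for cytotoxicity, read by crystal violet staining, with a stated time of 96 h (on this read-out lower numbers stand for higher toxicity in this test and higher numbers for lower toxicity in this test), compound 3 `CSCCCNC(=S)Nc1cccc(C(F)(F)F)c1` gives > 100000 nM, which is a limit and not a number. Compound 3 therefore stands at the limit of > 100000 nM in this assay, at which 1 of the 3 values shown sits. Compound 1 `FC(F)(F)c1cccc(NC(=S)Nc2ccccc2)c1` gives 39000 nM, and compound 2 `FC(F)(F)c1cccc(NC(=S)Nc2cccc(Br)c2)c1` gives 14000 nM. Compound 4 `FC(F)(F)c1cccc(NC(=S)Nc2ccccc2Br)c1` carries 2-bromophenyl in place of 3-(methylsulfanyl)propyl on an amide-type nitrogen. The opposite kind of change, putting the 3-(methylsulfanyl)propyl group in place of an aromatic group, gave an at least 2.5-fold higher number from compound 1 to compound 3 (0.40 log units; beyond the scatter) and an at least 7.1-fold higher number from compound 2 to compound 3 (0.85 log units; beyond the scatter). Adding bromo gave a 2.8-fold lower number from compound 1 to compound 2 (0.44 log units; beyond the scatter). Compound 4 is therefore expected to resemble compound 2 at 14000 nM, so a move to a lower number is expected in this assay. The expected step is an at least 6.2-fold lower number from compound 3 to compound 4 (0.79 log units; beyond the scatter). For compound 4 the estimate is 16000 nM, with an expected range of 6000 nM to 40000 nM.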

Compound 4, half-maximal cytotoxic concentration: 50000 nM
Compound 4: the middle estimate sits 3.1-fold (0.49 log units) below what was measured; the whole stated range lies below it.
By their numbers in this assay, from the lowest: compound 2; then compounds 1 and 4 (each within the scatter of the next). At a limit, above all of these: compound 3.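

Bromo does not lower the number wherever it sits in this assay: 2-bromophenyl in place of 3-bromophenyl gives a 3.6-fold higher number from compound 2 to compound 4 (0.55 log units; beyond the scatter), and 2-bromophenyl compared with plain phenyl gives a 1.3-fold higher number from compound 1 to compound 4 (0.11 log units; within the scatter). Replacing the 3-(methylsulfanyl)propyl chain with 2-bromophenyl gives an at least 2.0-fold lower number from compound 3 to compound 4 (0.30 log units; that floor lies within the scatter), which is only a floor. Compound 3 remains a limit and not a number: the limit of > 100000 nM in this assay, at which 1 of the 4 values shown sits.

Open, from the compounds shown here alone, is whether 2-chlorophenyl or 2-methoxyphenyl would behave like 2-bromophenyl. Also open, going by these compounds, is how a shorter chain or an amine-bearing chain on this nitrogen would read.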